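This account rests on a few compounds, and the source may have more. Where it says the series, first, only, none or still open, it means among the compounds named here.

In a functional assay on A549 cells (Homo sapiens) for cytotoxicity, read by MTT assay, with a stated time of 48 h (a higher number here means a weaker inhibitor, a lower number a stronger inhibitor), compound 3 (`O=c1ccc2cc(OCc3cn(-c4ccccc4)nn3)ccc2o1`) stands without a single number, its entry reading "not determined" (no result reported) for now. Compound 1 (`O=c1ccc2cc(OCc3cc(-c4ccc5ccccc5c4)no3)ccc2o1`) shows the same gap, with "not determined" (no result reported) as its entry. Only compound 2 (`N#Cc1ccccc1-c1cc(COc2ccc3oc(=O)ccc3c2)on1`) offers a figure, with 55800 nM as its result. Compound 4 (`COc1ccc(-n2cc(COc3ccc4oc(=O)ccc4c3)nn2)cc1`) carries a single change (methoxy in place of hydrogen on an aromatic carbon), methoxy in place of hydrogen on an aromatic carbon, para to a large group, turning phenyl into 4-methoxyphenyl. Among the compounds with values here, no measured pair shows what such a change does, so no shift beyond the usual scatter is expected in this assay in either direction. Within the data shown here, the sole guide is compound 2 at 55800 nM in that measurement. For compound 4 the estimated value is 45000 nM with an expected range from 15000 nM to 120000 nM around it.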

Compound 4, half-maximal inhibitory concentration: 46800 nM
The estimate for compound 4 lay 1.0-fold (0.02 log units) below the measured number; low and high end bracket the measured number.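

Compound 3 has no single number, so the change from it to compound 4 cannot be read as a step. As far as these compounds go, whether turning phenyl into 4-methoxyphenyl shifts cytotoxicity stays open. No supporting evidence bears on this result.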